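A few compounds are considered here, and "the series" means these few. Any claim that something is new, unique, unknown or untested is made for them only; others in the source may bear on it.

Among the measured compounds shown here, in a functional assay on KG-1a cells (Homo sapiens) for cytotoxicity, with a stated time of 24 h (on this read-out lower numbers stand for stronger inhibition and higher numbers for weaker inhibition), three compounds sharing one core have numbers so far. Compound 1 (`Nn1c(SCc2ccccc2[N+](=O)[O-])nnc1-c1c[nH]c2ccccc12`) gives 20800 nM, compound 2 (`Nn1c(SCc2cccc([N+](=O)[O-])c2)nnc1-c1c[nH]c2ccccc12`) gives 650 nM, and compound 3 (`Nn1c(SCc2ccc(F)cc2)nnc1-c1c[nH]c2ccccc12`) gives 13200 nM. Compound 3 thus stands within the scatter of compound 1, while compound 2 lies lower than compound 3 by a margin beyond the scatter. Compound 4 (`COc1ccc(CSc2nnc(-c3c[nH]c4ccccc34)n2N)cc1`) carries methoxy in place of fluoro on an aromatic carbon, para to a large group: methoxy in place of fluoro on an aromatic carbon. For the measured compounds named here, no measured pair shows this change, so no step beyond the scatter is expected in either direction. The estimated step, a 1.1-fold lower number from compound 3 to compound 4 (0.04 log units; within the scatter), is expected to stay small. For compound 4 the expected value is 12000 nM, within an estimated range of 4000 nM to 40000 nM.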

Compound 4, half-maximal inhibitory concentration: > 100000 nM
Compound 4: no number, only a limit (the forecaster's own chance of this, stated with the estimate: 10%); middle value at least 8.3-fold (0.92 log units) from the limit.
By their numbers in this assay, from the lowest: compound 2; then compounds 3 and 1 (each within the scatter of the next). At a limit, above all of these: compound 4.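

In this assay, the change from 4-fluorophenyl to 4-methoxyphenyl is not a neutral swap: it brings an at least 7.5-fold higher number from compound 3 to compound 4 (0.87 log units; beyond the scatter). This shows that the aromatic carbon para to a large group is sensitive to what it carries, and that adding methoxy there costs activity on this read-out. For compound 4 the assay gives > 100000 nM, which is a limit and not a number, so only the lower bound of the step is known.

Going by these compounds, whether a hydroxyl group or an amine on this carbon would behave like fluoro or like methoxy remains open.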